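Swapping the Indole for 4-Methoxyphenyl

The source may hold more compounds than are shown below. What is called first, only, known or untested is meant among the compounds shown, and "the series" means these compounds.

Compound 1 `COc1cc(-c2ccnc3cc(-c4cccc(C#N)c4)nn23)cc(OC)c1OC`: > 10000 nM
Compound 2 `COc1cc(-c2ccnc3cc(-c4ccc5ccn(C)c5c4)nn23)cc(OC)c1OC`: 829 nM

The two compounds were tested in a functional assay on A549 cells (Homo sapiens) for inhibition, read by CCK-8 assay, with a stated time of 48 h; on this read-out higher numbers stand for weaker inhibition and lower numbers for stronger inhibition. There, compound 1 gives > 10000 nM, which is a limit and not a number. Among the measured compounds shown here, compound 2, at 829 nM, holds the only actual number so far.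

Compound 3 `COc1ccc(-c2cc3nccc(-c4cc(OC)c(OC)c(OC)c4)n3n2)cc1` follows from compound 2 by one change: 4-methoxyphenyl in place of 1-methyl-1H-indol-6-yl on an aromatic carbon. For the measured compounds named here, one measured step bears on this place, an at least 12-fold lower number from compound 1 to compound 2 (1.08 log units; beyond the scatter), and it is large. It shows that the group at this place can matter greatly, and that the 1-methyl-1H-indol-6-yl group went with the stronger inhibition. With that group gone, a moderate move towards weaker inhibition is expected, though it is unlikely to go as far as the limit seen for compound 1. The expected change is a 3.6-fold higher number from compound 2 to compound 3 (0.56 log units; beyond the scatter). For compound 3 the estimated value is 3000 nM, with an expected range from 700 nM to 10000 nM.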

Compound 3, half-maximal inhibitory concentration: 376 nM
Beside the measured number, compound 3's estimate is 8.0-fold (0.90 log units) above it; measured number below the stated range.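

In this assay, the 1-methyl-1H-indol-6-yl group is not needed for inhibition at this aromatic carbon: 4-methoxyphenyl, with one six-membered aromatic ring of carbon only, does better, giving a 2.2-fold lower number from compound 2 to compound 3 (0.34 log units; beyond the scatter). The contrast with 3-cyanophenyl is also wider than the one seen with the indole, at an at least 26-fold lower number from compound 1 to compound 3 (1.42 log units; beyond the scatter). That step starts from a limit for compound 1 and not from a number, so its true size stays unknown: the limit of > 10000 nM in this assay, at which 1 of the 3 values shown sits.

The compounds shown leave open whether the methoxy group itself matters, as they offer no comparison with a plain phenyl, a 4-hydroxyphenyl or a 4-aminophenyl at this place. They also do not tell whether a 3-methoxyphenyl would behave like 4-methoxyphenyl or like 3-cyanophenyl.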